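The compounds below may be only part of what the source reports. "The series", "measured", "known", "first", "only" and "open" are said of these compounds alone.

Compound 1 `O=C(Nc1ccccc1)c1cn(Cc2c(F)cccc2F)c2ccc(=O)[nH]c2c1=O` gives 94 nM in an in vitro assay on Sf21 cells for inhibition of high affinity 3',5'-cyclic-AMP phosphodiesterase 7A (Homo sapiens), read by scintillation proximity assay, with a stated time of 30 min; a lower number here means a stronger inhibitor, a higher number a weaker inhibitor.
Compound 2 `N#Cc1ccc(NC(=O)c2cn(Cc3c(F)cccc3F)c3ccc(=O)[nH]c3c2=O)cc1` gives 96 nM in this assay.
Compound 3 `O=C(O)Cc1ccc(NC(=O)c2cn(Cc3c(F)cccc3F)c3ccc(=O)[nH]c3c2=O)cc1` gives 176 nM in this assay.

Compound 3 has the highest number of the three, yet its distance from compound 2 is a 1.8-fold higher number from compound 2 to compound 3 (0.26 log units; within the scatter) and from compound 1 is a 1.9-fold higher number from compound 1 to compound 3 (0.27 log units; within the scatter), both within the scatter, so the three stand level in this assay. Compound 4 `CS(=O)(=O)c1ccc(NC(=O)c2cn(Cc3c(F)cccc3F)c3ccc(=O)[nH]c3c2=O)cc1` differs from compound 3 by methylsulfonyl in place of carboxymethyl on an aromatic carbon. For the measured compounds named here, the steps that bear on this all change the same aromatic carbon: a 1.0-fold higher number from compound 1 to compound 2 (0.01 log units; within the scatter), a 1.9-fold higher number from compound 1 to compound 3 (0.27 log units; within the scatter) and a 1.8-fold higher number from compound 2 to compound 3 (0.26 log units; within the scatter), none of them beyond the scatter. The new step is therefore expected to be a 1.5-fold lower number from compound 3 to compound 4 (0.17 log units; within the scatter), again not beyond the scatter. Compound 4 is estimated at 120 nM, with a range from 50 nM to 300 nM.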

Compound 4, half-maximal inhibitory concentration: 27 nM
Compound 4: middle estimate off by 4.4-fold (0.65 log units), on the high side, outside the stated range (below it).
By their numbers in this assay, from the lowest: compound 4; then compounds 1, 2 and 3 (each within the scatter of the next).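

At this position, on an aromatic carbon para to a large group, the earlier changes stayed within the scatter, but methylsulfonyl takes the number in this assay beyond it (a 6.5-fold lower number from compound 3 to compound 4 (0.81 log units; beyond the scatter)) (a 3.6-fold lower number from compound 2 to compound 4 (0.55 log units; beyond the scatter)) (a 3.5-fold lower number from compound 1 to compound 4 (0.54 log units; beyond the scatter)). The position therefore does respond to the group placed there, and methylsulfonyl stands apart from hydrogen, cyano and carboxymethyl alike. Nothing available accounts for this difference.

As far as these compounds go, whether a sulfonamide or an ethylsulfonyl group would hold this level stays open. So does whether the same step would hold with other changes to the shared core.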